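The compounds below may be only part of what the source reports. "The series", "measured", "known", "first", "only" and "open" are said of these compounds alone.

Three compounds share one core and differ only in the group on the outer aromatic ring. In an ADME assay on RAW264.7 cells (Mus musculus) for cytotoxicity, read by MTT assay, with a stated time of 72 h, tested at 50 uM (on this read-out lower numbers stand for less inhibition and higher numbers for more inhibition at the one concentration tested (going by the name of the read-out)), compound 1 `CCOC(=O)c1sc(-c2ccccn2)nc1N1CCC(NCc2ccc(F)cc2)CC1` gives 12.6%, compound 2 `CCOC(=O)c1sc(-c2ccccn2)nc1N1CCC(NCc2ccc(OC)cc2)CC1` gives 4.62%, and compound 3 `CCOC(=O)c1sc(-c2ccccn2)nc1N1CCC(NCc2ccc(OCc3ccccc3)cc2)CC1` gives 12.8%. Among these three numbers compound 3 shows the highest figure, yet the step up to it is in one case a number 0.2 percentage points higher from compound 1 to compound 3 (within the scatter) and in the other case a number 8.2 percentage points higher from compound 2 to compound 3 (within the scatter), so all three values sit within the scatter of each other and no real difference in cell growth inhibition can be claimed.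

Compound 4 `CCOC(=O)c1sc(-c2ccccn2)nc1N1CCC(NCc2ccc(C(F)(F)F)cc2)CC1` has not yet been measured. Its change from compound 3 is trifluoromethyl in place of benzyloxy on an aromatic carbon. Going by the values given here, no measured step swaps in a trifluoromethyl, so the closest guide is that every change tried so far on this aromatic carbon, including a number 8 percentage points lower from compound 1 to compound 2 (within the scatter), stayed within the scatter. On that basis the step of a number 1.8 percentage points lower from compound 3 to compound 4 (within the scatter) is expected to be no larger than the scatter. Compound 4 is therefore estimated to give 11%, in the range from 2% to 22%.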

Compound 4, a percentage reported as inhibition, at one concentration (the size of the read-out at that concentration, not a potency): 14.6%
Compound 4: the middle estimate sits 3.6 percentage points below what was measured; the range from low to high includes it.
By their numbers in this assay, from the lowest: compounds 2, 1, 3 and 4 (each within the scatter of the next).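

Trifluoromethyl brings no ring and no hydrogen-bond acceptor, whereas benzyloxy brings a six-membered aromatic ring and one acceptor, yet this swap gives a number 1.8 percentage points higher from compound 3 to compound 4 (within the scatter) in this assay. Set against the two smaller groups, trifluoromethyl gives a number 2 percentage points higher from compound 1 to compound 4 (within the scatter) and a number 10 percentage points higher from compound 2 to compound 4 (within the scatter), so this aromatic carbon now carries four different groups and the read-out separates none of them at the one concentration tested. Nothing measured here offers an explanation for this flat picture.

From the compounds shown here alone, whether an amine or a carboxylic acid on this aromatic carbon would fit the same flat picture remains open. Going by these compounds, it is also open whether a change elsewhere on the shared core, such as an amide in place of the ethyl ester, would give a step beyond the scatter.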